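The source may hold more compounds than are shown below. What is called first, only, known or untested is meant among the compounds shown, and "the series" means these compounds.

Compound 2 `COC(=O)c1ccc(-c2cn(CC(=O)Nc3nc4ccccc4s3)nn2)cc1` is tested in a functional assay on BMDM cells (Mus musculus, strain C57BL/6) for inhibition, with a stated time of 2 days (a higher number here means a weaker inhibitor, a lower number a stronger inhibitor), and gives only a limit, > 30000 nM. Compound 1 `COc1ccc(-c2cn(CC(=O)Nc3cc(C)on3)nn2)cc1` likewise gives only a limit in this assay, > 30000 nM. Compound 2 therefore stands at the limit of this assay, where every shown value sits (the limit of > 30000 nM in this assay, at which 2 of the 2 values shown sit). Compound 3 `COC(=O)c1ccc(-c2cn(CC(=O)Nc3cc(C)on3)nn2)cc1` differs from compound 2 by 5-methyl-1,2-oxazol-3-yl in place of 1,3-benzothiazol-2-yl on an amide-type nitrogen. Within the data shown here, no measured step connects these compounds, so the expected step from compound 2 to compound 3 is a step that the limit leaves unreadable from compound 2 to compound 3, which means no change beyond the scatter. Compound 3 is accordingly expected to give about 50000 nM, between 20000 nM and 120000 nM, most likely again only a limit.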

Compound 3, half-maximal inhibitory concentration: > 30000 nM
Compound 3 ended at the assay's limit; the forecaster's own chance of this, stated with the estimate: 85%; the middle value does not contradict the limit.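

Compound 3 sits at the same limit as compound 1 and compound 2 in this assay, so neither step to compound 3 can be read: the limit of > 30000 nM in this assay, at which 3 of the 3 values shown sit. From the compounds shown here alone, whether either exchange changes inhibition in this assay remains open.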